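From Methylsulfanyl to Trifluoromethyl: an Expected Lipophilicity Shift

The source may hold more compounds than are shown below. What is called first, only, known or untested is meant among the compounds shown, and "the series" means these compounds.

Compound 1 `CSc1cccc(-c2nc(N)nc(N)n2)c1`: 2.16
Compound 2 `Nc1nc(N)nc(-c2c(Cl)cccc2Cl)n1`: 1.38

In a physicochemical assay for lipophilicity (on this read-out lower numbers stand for lower lipophilicity and higher numbers for higher lipophilicity), compound 1 gives 2.16, the higher of the two numbers. Compound 2 gives 1.38, which lies lower by more than the scatter. Compound 3 `Nc1nc(N)nc(-c2cccc(C(F)(F)F)c2)n1` has not yet been measured in this assay. It differs from compound 1 in one place: trifluoromethyl in place of methylsulfanyl on an aromatic carbon. Going by the values given here, no measured pair shows this exact change, so its size is not known from the data. A small rise is expected, a step of a number 0.24 log units higher from compound 1 to compound 3 (within the scatter), about at the edge of the usual scatter. Compound 3 is estimated at 2.4, with a range from 2 to 2.8.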

Compound 3, partition coefficient: 2.67
Beside the measured number, compound 3's estimate is 0.27 log units below it; the range from low to high includes it.
By their numbers in this assay, from the lowest: compound 2; then compound 1; then compound 3.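

Trifluoromethyl in place of methylsulfanyl on this aromatic carbon gives a number 0.51 log units higher from compound 1 to compound 3 (beyond the scatter) in this assay and so puts a measured size on this change for the first time. That size rests on a single pair, compound 1 and compound 3, which share the rest of their structure. Nothing measured here explains the step. As far as these compounds go, whether the same change would give a similar step on a different core stays open. From the compounds shown here alone, how an amine, a carboxylic acid or a longer chain in this place would compare also stays open.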